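Stereochemical variation on the sugar-derived somatostatin scaffold

The source may hold more compounds than are shown below. What is called first, only, known or untested is meant among the compounds shown, and "the series" means these compounds.

Measured so far:
compound 1 `CS[C@@H]1O[C@H](COCc2ccc(Cl)cc2)[C@@H](O)[C@@H](OCc2ccc3ccccc3c2)[C@H]1NC(=O)CCN`: 980 nM
compound 2 `COC[C@H]1O[C@H](OCCc2ccccc2)[C@H](NC(=O)CCCN)[C@H](OCc2ccc3ccccc3c2)[C@@H]1O`: 6100 nM

Two compounds have been run in an assay on CHO cells for displacement of a labelled ligand from somatostatin receptor type 2 (Homo sapiens); a higher number here means a weaker inhibitor, a lower number a stronger inhibitor. Compound 1 gives 980 nM. Compound 2 gives 6100 nM, the higher of the two numbers; its nearest neighbour is compound 1, which lies well apart from it, beyond the usual scatter. Compound 2 and compound 1 differ in several places at once, so no single change can be read from that pair.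

Compound 3 `COC[C@H]1O[C@@H](OCCc2ccccc2)[C@H](NC(=O)CCCN)[C@@H](OCc2ccc3ccccc3c2)[C@@H]1O` keeps every atom and bond of compound 2: the two compounds have the same atoms and bonds and differ only in configuration as drawn: 2 of 5 stereo elements differ; a stereocentre at a saturated ring carbon is drawn S in compound 2 and R in compound 3; a stereocentre at a saturated ring carbon is drawn S in compound 2 and R in compound 3. For the measured compounds named here, nothing among the measured pairs isolates a configurational change, so no step size can be taken from the data. A change of configuration at two ring carbons may move the number either way; the expectation for the step of a 1.5-fold lower number from compound 2 to compound 3 (0.18 log units; within the scatter) is therefore a modest shift, wide in uncertainty, with no clear direction beyond the scatter. For compound 3 the estimated value in this assay is 4000 nM, in the range 800 nM to 20000 nM.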

Compound 3, half-maximal inhibitory concentration: 3320 nM
The estimate for compound 3 lay 1.2-fold (0.08 log units) above the measured number; the measured number falls inside the stated range.
By their numbers in this assay, from the lowest: compound 1; then compounds 3 and 2 (each within the scatter of the next).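

The pair gives the series its first step that isolates configuration, because no other structural difference enters the comparison: the fact that compounds 2 and 3 differ only in the configuration as drawn

In this assay, changing the drawn configuration at two saturated ring carbons together gives a 1.8-fold lower number from compound 2 to compound 3 (0.26 log units; within the scatter), so this double change does not separate the two compounds. With this side chain and these ring substituents, the number therefore shows no clear dependence on the configuration of these two carbons taken together.

The pair cannot show what either ring carbon does alone, since opposing effects at the two centres would look the same as no effect at either. It also leaves open whether the same double change would stay within the scatter with a guanidine or a carboxylic acid in place of the side-chain amine.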